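Swapping the fluorinated aryl ring for a chlorophenyl group

The source may hold more compounds than are shown below. What is called first, only, known or untested is meant among the compounds shown, and "the series" means these compounds.

Measured compounds:
compound 1, `CC(C)(C)Cc1c(-c2ccc(F)cc2)sc(N)c1C(=O)c1ccc(Cl)cc1`, 9%
compound 2, `CC(C)(C)Cc1c(-c2cccc(F)c2F)sc(N)c1C(=O)c1ccc(Cl)cc1`, 1%

In an assay on CHO cells for displacement of a labelled ligand from adenosine receptor A3 (Homo sapiens), read by scintillation counting, tested at 10 uM (a lower number here means less inhibition, a higher number more inhibition at the concentration tested (going by the name of the read-out)), compound 2 gives the lowest of the two numbers; its nearest neighbour is compound 1, and the step of a number 8 percentage points lower from compound 1 to compound 2 (within the scatter) lies within the scatter, so the two compounds cannot be told apart on these numbers. Compound 3, `CC(C)(C)Cc1c(-c2ccc(Cl)cc2)sc(N)c1C(=O)c1ccc(Cl)cc1`, has not yet been measured. It differs from compound 2 by 4-chlorophenyl in place of 2,3-difluorophenyl on an aromatic carbon. For the measured compounds named here, the only measured step that bears on this change is a number 8 percentage points lower from compound 1 to compound 2 (within the scatter), which exchanged one halogenated phenyl ring for another on the same aromatic carbon and produced no movement beyond the scatter. Compound 3 returns to a ring halogenated in the same pattern as compound 1, with chlorine in place of fluorine. A step of a number 7 percentage points higher from compound 2 to compound 3 (within the scatter) is therefore expected, staying within the scatter. For compound 3 the estimate is 8%, between -5% and 22%.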

Compound 3, a percentage reported as inhibition, at one concentration (the size of the read-out at that concentration, not a potency): 1%
Beside the measured number, compound 3's estimate is 7 percentage points above it; the measured number falls inside the stated range.
By their numbers in this assay, from the lowest: compounds 2, 3 and 1 (each within the scatter of the next).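

In this assay, the step of no change at the digits printed from compound 2 to compound 3 (within the scatter) shows that 4-chlorophenyl and 2,3-difluorophenyl cannot be told apart on this aromatic carbon next to the ring sulfur. For the compounds shown here, the step of a number 8 percentage points lower from compound 1 to compound 3 (within the scatter) adds a comparison that the earlier compounds did not offer: with chloro in place of fluoro on an aromatic carbon, the two compounds again cannot be told apart, so all three halogenated phenyl groups read alike here. Nothing measured here offers a reason for this sameness. As far as these compounds go, whether a phenyl ring carrying an amine or a carboxylic acid, or a methoxy group in place of the halogen, would read differently at this place remains open. So does the effect of replacing the neopentyl group with a longer chain.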